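Swapping one ring group on compound 2

This account rests on a few compounds, and the source may have more. Where it says the series, first, only, none or still open, it means among the compounds named here.

Measured in a functional assay on AGS cells (Homo sapiens) for antiproliferative activity, read by MTT assay, with a stated time of 48 h; a lower number here means a stronger inhibitor of growth, a higher number a weaker inhibitor of growth:
Compound 1 `COc1ccc(N(C)c2ncnc3c2ncn3Cc2cc(OC)cc(OC)c2)cc1` gives > 100000 nM as a limit
Compound 2 `COc1ccc(Cn2cnc3c(N(C)c4ccc(OC)cc4)nc(Cl)nc32)cc1` gives > 100000 nM as a limit

Both entries are limits of the assay and not numbers. Compound 2 stands at the limit of > 100000 nM in this assay, at which 2 of the 2 values shown sit, and so offers no number to step from.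

Compound 3 `COc1ccc(N(C)c2nc(Cl)nc3c2ncn3Cc2cc(OC)cc(OC)c2)cc1` carries 3,5-dimethoxyphenyl in place of 4-methoxyphenyl on a saturated chain carbon bound to an aromatic nitrogen. It has not yet been measured.

Among the measured compounds shown here, no measured step shows what such a swap does in this assay and only a small shift is expected. Any visible shift should run toward stronger inhibition of growth, and compound 3 may well return a limit too. The estimated change is an at least 1.6-fold lower number from compound 2 to compound 3 (0.22 log units; that floor lies within the scatter) and it remains uncertain. For compound 3 the estimated value is 60000 nM with 5000 nM to 100000 nM as the expected range.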

Compound 3, concentration for 50% growth inhibition: 69000 nM
Compound 3: the middle estimate sits 1.2-fold (0.06 log units) below what was measured; low and high end bracket the measured number.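

In this assay compound 3 gives 69000 nM as a true number, the first in this set. Compound 1 and compound 2 gave only limits. Chloro in place of hydrogen on an aromatic carbon gives an at least 1.4-fold lower number from compound 1 to compound 3 (0.16 log units; that floor lies within the scatter) and 3,5-dimethoxyphenyl in place of 4-methoxyphenyl gives an at least 1.4-fold lower number from compound 2 to compound 3 (0.16 log units; that floor lies within the scatter) as steps known only by their floors. Both floors lie within the scatter, so these compounds show that the two groups together reach a readable number, while neither step can yet be sized.

Which of the two changes matters more remains open. Also open, going by these compounds, is how the number would move with an amine or a longer chain in place of the chloro, or with a carboxylic acid on the phenyl ring.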